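Amino for chloro on the fused ring of compound 2

A few compounds are considered here, and "the series" means these few. Any claim that something is new, unique, unknown or untested is made for them only; others in the source may bear on it.

Compound 1 `Nc1nn(C(=O)Nc2ccc(Cc3ccccc3)cc2)c2ccccc12`; in a functional assay on NCI-H226 cells (Homo sapiens) for antiproliferative activity, read by sulforhodamine B assay, with a stated time of 48 h (on this read-out lower numbers stand for higher toxicity in this test and higher numbers for lower toxicity in this test), compound 1 gives > 100000 nM, a limit of the assay and not a number.
Compound 2 `Nc1nn(C(=O)Nc2ccc(Cc3ccccc3)cc2)c2ccc(Cl)cc12`; in this assay compound 2 gives > 100000 nM, again a limit of the assay.

Both values sit at the same limit, (the limit of > 100000 nM in this assay, at which 2 of the 2 values shown sit), so the step that the two limits leave unreadable from compound 1 to compound 2 cannot be read; chloro in place of hydrogen on an aromatic carbon leaves no readable trace. Compound 2 therefore stands only at a limit, with no number attached.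

Compound 3 `Nc1ccc2c(c1)c(N)nn2C(=O)Nc1ccc(Cc2ccccc2)cc1` differs from compound 2 by amino in place of chloro on an aromatic carbon. Going by the values given here, the only measured step touches the same position of the core, but it is unreadable because the limit of > 100000 nM in this assay, at which 2 of the 2 values shown sit, holds both of its ends. There is thus no measured basis for a step of any size in this assay, and the most likely outcome is a further limit. Compound 3 is expected to give 150000 nM, with a range from 40000 nM to 600000 nM. For compound 3 the expected step is a step that the limit leaves unreadable from compound 2 to compound 3.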

Compound 3, concentration lethal to 50% of the cells: 91400 nM
Beside the measured number, compound 3's estimate is 1.6-fold (0.22 log units) above it; low and high end bracket the measured number.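

In this assay, going by these compounds alone, compound 3 is the first to carry a number and not a limit, so a change on this aromatic carbon of the shared core now has one readable end. Amino in place of chloro gives an at least 1.0-fold lower number from compound 2 to compound 3 (0.03 log units; that floor lies within the scatter), and amino in place of hydrogen gives an at least 1.0-fold lower number from compound 1 to compound 3 (0.03 log units; that floor lies within the scatter); both are floors only, so neither step shows a change beyond the scatter, and the true size of each stays unknown. Compound 1 and compound 2 remain limits and not numbers: the limit of > 100000 nM in this assay, at which 2 of the 3 values shown sit.

Still open, from the compounds shown here alone, is how far the true values of compound 1 and compound 2 lie from that of compound 3. Also open, going by these compounds, is whether a methoxy group or a carboxylic acid on this aromatic carbon would give a step clearly beyond the scatter.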